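The compounds below may be only part of what the source reports. "The series", "measured", "known", "first", "only" and "open" are said of these compounds alone.

In a functional assay on SGC-7901 cells (Homo sapiens) for cytotoxicity, read by MTT assay, with a stated time of 48 h (a higher number here means a weaker inhibitor, a lower number a stronger inhibitor), compound 1 (`Cc1ncc([N+](=O)[O-])n1CCSc1nnc(-c2ccc(N)cc2)o1`) gives 31700 nM, compound 2 (`Cc1ncc([N+](=O)[O-])n1CCSc1nnc(-c2ccccc2F)o1`) gives 33700 nM and compound 3 (`Cc1ncc([N+](=O)[O-])n1CCSc1nnc(-c2ccc(Cl)cc2)o1`) gives 31900 nM. Compound 3 therefore stands level with both others, within the scatter. Compound 4 (`Cc1ccc(-c2nnc(SCCn3c([N+](=O)[O-])cnc3C)o2)c(O)c1`) carries 2-hydroxy-4-methylphenyl in place of 4-chlorophenyl on an aromatic carbon, (2-hydroxy-4-methylphenyl in place of 4-chlorophenyl on an aromatic carbon). The nearest measured changes are small: a 1.0-fold higher number from compound 1 to compound 3 (0.00 log units; within the scatter), a 1.1-fold lower number from compound 2 to compound 3 (0.02 log units; within the scatter) and a 1.1-fold higher number from compound 1 to compound 2 (0.03 log units; within the scatter), each within the scatter. For the measured compounds named here, no measured compound carries the entering group, so the range stays wide. No step beyond the scatter is expected in this assay. The estimated change is a 1.1-fold lower number from compound 3 to compound 4 (0.03 log units; within the scatter). Compound 4 is expected at 30000 nM, with an estimated range of 14000 nM to 65000 nM.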

Compound 4, half-maximal inhibitory concentration: 36700 nM
Beside the measured number, compound 4's estimate is 1.2-fold (0.09 log units) below it, within the range that was stated.
By their numbers in this assay, from the lowest: compounds 1, 3, 2 and 4 (each within the scatter of the next).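

In this assay, the aromatic carbon of the five-membered ring also takes 2-hydroxy-4-methylphenyl, a phenyl with two substituents, without a step beyond the scatter: a 1.2-fold higher number from compound 3 to compound 4 (0.06 log units; within the scatter), a 1.1-fold higher number from compound 2 to compound 4 (0.04 log units; within the scatter) and a 1.2-fold higher number from compound 1 to compound 4 (0.06 log units; within the scatter). The four aryl groups in compounds 1 to 4 therefore stand level, and the hydroxy and methyl pair does not separate from the single amino, fluoro or chloro substituents. No evidence on the reason for this flat response is at hand.

Going by these compounds, whether it persists with a carboxylic acid or a longer alkyl chain in place of the aryl group remains open. On these data alone, the separate contributions of the hydroxy and methyl groups also remain open.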